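A few compounds are considered here, and "the series" means these few. Any claim that something is new, unique, unknown or untested is made for them only; others in the source may bear on it.

Among the measured compounds shown here, compound 1 `COc1ccc2c(-c3cc(C(F)(F)F)c(C#N)c(-c4cn(S(=O)(=O)c5ccc(C)cc5)c5cc(OC)ccc45)n3)cn(S(=O)(=O)c3ccc(C)cc3)c2c1` and compound 2 `Cc1ccc(S(=O)(=O)n2cc(-c3cc(C(F)(F)F)cc(-c4cn(S(=O)(=O)c5ccc(C)cc5)c5ccccc45)n3)c3ccccc32)cc1` are the two members so far measured in a functional assay on A549 cells (Homo sapiens) for inhibition, tested at 0.1 uM; on this read-out higher numbers stand for a stronger effect at the one concentration tested and lower numbers for a weaker effect. In this assay compound 1 gives 33%. In this assay compound 2 gives 37.5%, a value within the usual scatter of that of compound 1, so the two cannot be ranked against each other. Compound 3 `COc1ccc2c(-c3cc(C(F)(F)F)cc(-c4cn(S(=O)(=O)c5ccc(C)cc5)c5cc(OC)ccc45)n3)cn(S(=O)(=O)c3ccc(C)cc3)c2c1` has not yet been measured. Compound 3 differs from compound 1 by hydrogen in place of cyano on an aromatic carbon. For the measured compounds named here, no measured pair shows this change on its own. The step of a number 2 percentage points higher from compound 1 to compound 3 (within the scatter) is expected to be small, in no clear direction, and not beyond the scatter. Compound 3 is accordingly estimated at 35%, with a range from 20% to 50%.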

Compound 3, a percentage reported as inhibition, at one concentration (the size of the read-out at that concentration, not a potency): 1.7%
For compound 3 the middle estimate is 33.3 percentage points above the measured one, outside the stated range (below it).
By their numbers in this assay, from the lowest: compound 3; then compounds 1 and 2 (each within the scatter of the next).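

In this assay the aromatic carbon ortho to a trifluoromethyl group and two atoms from the ring nitrogen proves sensitive, with a number 31.3 percentage points lower from compound 1 to compound 3 (beyond the scatter) on putting hydrogen in place of cyano. Among the compounds shown here, this is the first change in one place, and it shows that on the core of compound 1 the cyano group cannot be dropped without losing the read-out at the one concentration tested. Nothing available bears on the cause of this step. Open, going by these compounds, is whether an amine, a carboxylic acid or a methyl group at this carbon would hold the read-out. Also open, on these data alone, is whether cyano has a comparable effect on the core of compound 2.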